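From but-3-en-1-yl to 4-fluorobenzyl on a shared core

The source may hold more compounds than are shown below. What is called first, only, known or untested is meant among the compounds shown, and "the series" means these compounds.

In a functional assay on BV-2 cells (Mus musculus), read by Griess assay, with a stated time of 24 h (a higher number here means a weaker inhibitor, a lower number a stronger inhibitor), compound 1 `O=C1C=CC2(C=C1)OCCC(=O)N2c1ccccc1` gives 1300 nM, compound 2 `C=CCC1COC2(C=CC(=O)C=C2)N(c2ccccc2)C1=O` gives 1030 nM and compound 3 `C=CCCC1COC2(C=CC(=O)C=C2)N(c2ccccc2)C1=O` gives 730 nM. Compound 3 sits within the scatter of both others. Compound 4 `O=C1C=CC2(C=C1)OCC(Cc1ccc(F)cc1)C(=O)N2c1ccccc1` differs from it as follows: 4-fluorophenyl in place of allyl on a saturated chain carbon bound to a saturated ring carbon. In words, this is 4-fluorophenyl in place of allyl on a saturated chain carbon bound to a saturated ring carbon. The closest evidence is a 1.8-fold lower number from compound 1 to compound 3 (0.25 log units; within the scatter) and a 1.4-fold lower number from compound 2 to compound 3 (0.15 log units; within the scatter), both within the scatter. Neither step brought in an aromatic ring, so the guide is only partial. On these steps alone, no change beyond the scatter is expected in this assay. The estimated step is a 1.2-fold lower number from compound 3 to compound 4 (0.09 log units; within the scatter). For compound 4 the expected value is 600 nM, with an estimated range of 200 nM to 1800 nM.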

Compound 4, half-maximal inhibitory concentration: 400 nM
Beside the measured number, compound 4's estimate is 1.5-fold (0.18 log units) above it, and the stated range covers the measured number.
By their numbers in this assay, from the lowest: compounds 4, 3, 2 and 1 (each within the scatter of the next, the first and the last beyond it).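

Against hydrogen on this saturated ring carbon, 4-fluorobenzyl, unlike allyl or but-3-en-1-yl, clears the scatter in this assay with a 3.3-fold lower number from compound 1 to compound 4 (0.51 log units; beyond the scatter) as its step. It also clears the scatter against allyl, with a 2.6-fold lower number from compound 2 to compound 4 (0.41 log units; beyond the scatter) as the step, but not against but-3-en-1-yl, with a 1.8-fold lower number from compound 3 to compound 4 (0.26 log units; within the scatter) as the step. Nothing available explains these differences. On these data alone, it remains open whether the fluorine contributes, which plain benzyl would test. Also open, as far as these compounds go, is how a longer chain ending in a phenyl ring or an amine would read at this position.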